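The compounds below may be only part of what the source reports. "The series", "measured", "known", "first", "only" and "open" are said of these compounds alone.

Measured so far in a functional assay on WM 266-4 cells (Homo sapiens) for antiproliferative activity, read by MTT assay, with a stated time of 48 h; a higher number here means a weaker inhibitor of growth, a lower number a stronger inhibitor of growth:
compound 1 `Fc1ccc(C2=NN(C(=S)Nc3ccccc3)C(c3ccc4c(c3)OCCO4)C2)cc1`: 22500 nM
compound 2 `S=C(Nc1ccccc1)N1N=C(c2ccc(Br)cc2)CC1c1ccc2c(c1)OCCO2`: 870 nM

Compound 1 stands at the highest of the two numbers in this assay; its nearest neighbour is compound 2, reached by a 26-fold lower number from compound 1 to compound 2 (1.41 log units; beyond the scatter), with bromo in place of fluoro on an aromatic carbon. Compound 3 `COc1cccc(C2=NN(C(=S)Nc3ccccc3)C(c3ccc4c(c3)OCCO4)C2)c1` is not yet measured. It differs from compound 1 by 3-methoxyphenyl in place of 4-fluorophenyl on a carbon with a double bond to nitrogen.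

For the measured compounds named here, the one measured step alters the same aryl group that is changed here, and it was large, but it swapped one halogen for another and carries no information on a methoxy group or on a different ring position. Going by the values given here, no measured step therefore bears directly on the change from compound 1 to compound 3. What the data do show is that numbers in this assay respond strongly to what sits on this aryl group, so a step beyond the scatter in either direction is possible, and the estimate is kept near compound 1 with a wide range. Compound 3 is expected to give 9000 nM in this assay, within 1500 nM to 45000 nM. This estimate means an expected step of a 2.5-fold lower number from compound 1 to compound 3 (0.40 log units; beyond the scatter).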

Compound 3, concentration for 50% growth inhibition: 1380 nM
For compound 3 the middle estimate is 6.5-fold (0.81 log units) above the measured one; measured number outside the range, below it.
By their numbers in this assay, from the lowest: compounds 2 and 3 (each within the scatter of the next); then compound 1.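

In this assay, a second replacement on the carbon with a double bond to nitrogen gives a 16-fold lower number from compound 1 to compound 3 (1.21 log units; beyond the scatter), and 3-methoxyphenyl in place of 4-fluorophenyl brings in no halogen at all, so a large step at this position is not confined to an exchange of one halogen for another. Comparing the two groups that give the lower numbers, 3-methoxyphenyl in place of 4-bromophenyl gives a 1.6-fold higher number from compound 2 to compound 3 (0.20 log units; within the scatter), so these two differently substituted aryl groups cannot be told apart in this assay, and among the three compounds shown the 4-fluorophenyl of compound 1 is the only group that stands apart. No measurement on hand explains these steps.

The replacement in compound 3 alters both the substituent and its place on the ring, so the shares of the methoxy group and of its ring place in the step remain unseparated. Also open, from the compounds shown here alone, is how this carbon would tolerate an unsubstituted phenyl, or a phenyl bearing an amine or a carboxylic acid, and whether the low numbers extend to such groups.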